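The compounds below may be only part of what the source reports. "The series", "measured", "known", "first", "only" and "open" are said of these compounds alone.

Compound 3 `Clc1ccc(/C=N/c2sc3c(c2-c2nc4ccccc4s2)CCCC3)cc1` is measured in an ADME assay on cells (Rhabdomyosarcoma cell, Homo sapiens) for cytotoxicity, read by MTT assay, with a stated time of 72 h (a higher number here means that more compound is tolerated, a lower number that less compound is tolerated), where compound 3 gives 367 ug/mL. Compound 1 `Nc1sc2c(c1-c1nc3ccccc3s1)CCCC2` gives 253 ug/mL and compound 2 `Clc1ccc(/C=N/c2sc3c(c2-c2nc4ccccc4s2)CCC3)cc1` gives 342 ug/mL in this assay, so compound 3 sits within the scatter of both. Within the data shown here, the only step that touches this part of the structure is a 1.5-fold higher number from compound 1 to compound 3 (0.16 log units; within the scatter), which adds the whole arylidene group; compound 4 `Fc1ccccc1/C=N/c1sc2c(c1-c1nc3ccccc3s1)CCCC2` keeps it and only swaps the aryl, namely (2-fluorophenyl in place of 4-chlorophenyl on a carbon with a double bond to nitrogen). Among the measured compounds shown here, no measured step bears on that swap directly. Since adding the aryl group itself moved the number little, compound 4 is expected to show no step beyond the scatter, estimated as a 1.1-fold lower number from compound 3 to compound 4 (0.03 log units; within the scatter), so compound 4 is expected at 340 ug/mL, between 200 ug/mL and 560 ug/mL.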

Compound 4, half-maximal cytotoxic concentration: 319 ug/mL
Estimate against measurement, compound 4: 1.1-fold (0.03 log units) above, and the stated range covers the measured number.
By their numbers in this assay, from the lowest: compounds 1, 4, 2 and 3 (each within the scatter of the next).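

In this assay the swap of 4-chlorophenyl for 2-fluorophenyl on a carbon with a double bond to nitrogen gives a 1.2-fold lower number from compound 3 to compound 4 (0.06 log units; within the scatter) and so shows that this aryl can change in both its halogen and its place of substitution without a step beyond the scatter. Set against the free amine of the core, the 2-fluorophenyl group gives a 1.3-fold higher number from compound 1 to compound 4 (0.10 log units; within the scatter) and stays within the scatter as well. Nothing measured offers an explanation for these small steps. From the compounds shown here alone, whether an aryl carrying a carboxylic acid or an amine, or a longer chain in place of the aryl, would also stay within the scatter remains open.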